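Swapping fluoro for methoxy on compound 3

This account rests on a few compounds, and the source may have more. Where it says the series, first, only, none or still open, it means among the compounds named here.

In a functional assay on HO8910 cells (Homo sapiens) for inhibition, read by MTT assay, with a stated time of 24 h, tested at 1 ug/mL (a lower number here means less inhibition of growth, a higher number more inhibition of growth at the concentration tested), compound 1 (`CC(=O)SCCC(CCCCC(=O)O)SC(C)=O`) is reported as "not active" (no number reported) and has no single number. Compound 2 (`O=C(O)CCCCC(CCSC(=O)c1ccccc1)SC(=O)c1ccccc1`) gives 0.29% in the same test. Compound 3 (`O=C(CCCCC(S)CCS)Nc1ccc(F)cc1`) gives 12.2% as the higher of the two numbers, a gap beyond the usual scatter. Compound 4 (`COc1ccc(NC(=O)CCCCC(S)CCS)cc1`) shares the core of compound 3 but carries methoxy in place of fluoro on an aromatic carbon, para to a large group (methoxy in place of fluoro on an aromatic carbon). Within the data shown here, no measured pair shows what this exchange does, so the estimated step (a number 2.2 percentage points lower from compound 3 to compound 4 (within the scatter)) stays within the scatter, with no favoured direction. In this assay compound 4 is therefore expected at 10% with a range from 3% to 22% for now.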

Compound 4, percent growth inhibition at one concentration: 1.79%
Estimate against measurement, compound 4: 8.2 percentage points above; the whole stated range lies above it.
By their numbers in this assay, from the lowest: compounds 2 and 4 (each within the scatter of the next); then compound 3.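

Among these compounds, exchanging fluoro for methoxy on the aromatic ring, para to a large group, gives the first measured step at this position in this assay (a number 10.4 percentage points lower from compound 3 to compound 4 (beyond the scatter)). Among the compounds shown here, for this pair, then, the group at this place matters to the read-out, which the earlier compounds could not show. No measurement offered here accounts for the step.

On these data alone, whether an amine or a chloro at the same place would give a number closer to compound 3 or to compound 4 stays open. So does whether this exchange would do the same on another core.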